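Ester change from compound 1 to compound 4

The compounds below may be only part of what the source reports. "The series", "measured", "known", "first", "only" and "open" are said of these compounds alone.

Measured so far in an assay on nucleic acid for inhibition of Nucleic Acid, read by fluorescence, tested at 100 uM; a lower number here means less inhibition, a higher number more inhibition at the concentration tested (going by the name of the read-out):
- compound 1 `CCCCCCCC(=O)OCC(O)Cn1cc(CN2CCN(c3ccccc3)CC2)nn1`: 26%
- compound 2 `O=C(NCc1ccccc1)OCC(O)Cn1cc(CN2CCC(c3ccccc3)CC2)nn1`: 29%
- compound 3 `CCOC(=O)C1CCCN(Cc2cn(CC(O)COC(=O)c3ccccc3)nn2)C1`: 6%

Compound 1 stands second highest of the three numbers. Its nearest neighbour is compound 2, whose number lies within the scatter of compound 1, so no order between the two can be read. Going by the values given here, compound 3 is the furthest from compound 1, with a number beyond the scatter below it; compound 3 differs from compound 1 in more than one place, so its value alone is known and no single step can be drawn from it.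

Compound 4 `O=C(OCC(O)Cn1cc(CN2CCN(c3ccccc3)CC2)nn1)c1ccccc1` is not yet measured. It differs from compound 1 in one place: phenyl in place of heptyl on a carbonyl carbon. Among the compounds with values here, no measured pair shows this change on its own. Compound 3 also carries a benzoyloxy group, but with a different amine, so it gives no clean guide. The expected step of a number 6 percentage points lower from compound 1 to compound 4 (within the scatter) is small and downward, likely within the scatter. Compound 4 is therefore expected to give 20% in this assay, with a range from 5% to 36%.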

Compound 4, a percentage reported as inhibition, at one concentration (the size of the read-out at that concentration, not a potency): 11%
For compound 4 the middle estimate is 9 percentage points above the measured one; measured number inside the range.
By their numbers in this assay, from the lowest: compounds 3 and 4 (each within the scatter of the next); then compounds 1 and 2 (each within the scatter of the next).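

In this assay, phenyl in place of heptyl on a carbonyl carbon gives a number 15 percentage points lower from compound 1 to compound 4 (beyond the scatter). Going by these compounds alone, this is the first step that changes one place only, and it shows that the read-out responds to the group on this carbonyl carbon, with heptyl giving the higher number on this core. Nothing available gives a reason for the step.

This single pair cannot separate the loss of the chain from the arrival of the aromatic ring; an acetyl group, a longer chain or a cyclohexyl group at the same place would bear on that. Also open, on these data alone, is whether the step carries over to other amines on the shared core, such as a morpholine, and what a carboxylic acid or an amide would give in place of the ester.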